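The compounds below may be only part of what the source reports. "The series", "measured", "known", "first", "only" and "open" are said of these compounds alone.

Measured compounds:
compound 1 `CCCC(C)n1c(CC)nc2c(-c3ccc(OC)nc3C(F)(F)F)ccnc21`; in an assay for binding affinity to Corticotropin releasing factor receptor (Rattus norvegicus) (a higher number here means a weaker inhibitor, a lower number a stronger inhibitor), compound 1 gives 0.6 nM
compound 2 `CCCC(C)n1c(CC)nc2c(-c3ccc(O)nc3C(F)(F)F)ccnc21`; compound 2 gives 602 nM
compound 3 `CCCC(C)n1c(CC)nc2c(-c3ccc(OCC(=O)OCC)nc3C(F)(F)F)ccnc21`; compound 3 gives 1050 nM

Compound 3 gives the highest number of the three. Its nearest neighbour is compound 2, the step of a 1.7-fold higher number from compound 2 to compound 3 (0.24 log units; within the scatter) lying within the scatter, while compound 1 stands far off, as a 1800-fold higher number from compound 1 to compound 3 (3.24 log units; beyond the scatter) shows. Compound 4 `CCCC(C)n1c(CC)nc2c(-c3ccc(OCCO)nc3C(F)(F)F)ccnc21` is not yet measured; it differs from compound 3 by hydroxymethyl in place of ethoxycarbonyl on a saturated chain carbon bound to an oxygen on an aromatic ring. Within the data shown here, two measured steps bear on this. Each departure from the methyl on the oxygen on the aromatic ring of compound 1 has cost heavily: a 1000-fold higher number from compound 1 to compound 2 (3.00 log units; beyond the scatter) and a 1800-fold higher number from compound 1 to compound 3 (3.24 log units; beyond the scatter). Compound 4 keeps an extended chain on that oxygen, so it sits on the weak side of that divide. Within the weak side, the one comparison available, a 1.7-fold higher number from compound 2 to compound 3 (0.24 log units; within the scatter), stayed within the scatter. Among the measured compounds shown here, no step tells what hydroxymethyl itself does in place of ethoxycarbonyl. For compound 4 the expected step of a 1.5-fold lower number from compound 3 to compound 4 (0.18 log units; within the scatter) is therefore not beyond the scatter. Compound 4 is estimated at 700 nM, within 150 nM to 3500 nM.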

Compound 4, inhibition constant: 10.1 nM
Compound 4: middle estimate off by 69-fold (1.84 log units), on the high side, and the stated range ends above it.
By their numbers in this assay, from the lowest: compound 1; then compound 4; then compounds 2 and 3 (each within the scatter of the next).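

In this assay the chain on the oxygen on the aromatic ring no longer falls on a single weak side: replacing the ethoxycarbonyl of compound 3 with hydroxymethyl gives a 100-fold lower number from compound 3 to compound 4 (2.02 log units; beyond the scatter) and 2-hydroxyethyl in place of hydrogen gives a 60-fold lower number from compound 2 to compound 4 (1.78 log units; beyond the scatter) in this series. The methyl of compound 1 still holds the lowest number, with a 17-fold higher number from compound 1 to compound 4 (1.23 log units; beyond the scatter) marking how much of the gap stays unrecovered by the 2-hydroxyethyl chain. Nothing on hand explains why these two chains on the same oxygen differ so sharply.

Going by these compounds, whether the step follows from the hydroxyl of the 2-hydroxyethyl chain or from the loss of the ethoxycarbonyl stays open, and a 2-methoxyethyl or plain ethyl group on that oxygen would separate the two. On these data alone, how a carboxylic acid, an amine or a longer chain such as 3-hydroxypropyl would read at this place also stays open.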